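Furan to Phenyl Swap on a Pyridine-Free Named Core

This account rests on a few compounds, and the source may have more. Where it says the series, first, only, none or still open, it means among the compounds named here.

Compound 1 `Oc1ccc(-c2cc(-c3ccccc3)nc(-c3ccccc3Cl)c2)cc1` gives 4990 nM in a functional assay on HCT-15 cells (Homo sapiens) for cytotoxicity, read by CCK-8 assay and cell counting, with a stated time of 2 days; on this read-out lower numbers stand for stronger inhibition and higher numbers for weaker inhibition. Compound 2 `Oc1ccc(-c2cc(-c3ccco3)nc(-c3ccccc3Cl)c2)cc1` gives 5460 nM in this assay. Compound 3 `Oc1ccc(-c2cc(-c3cccc(Cl)c3)nc(-c3ccco3)c2)cc1` gives 8020 nM in this assay.

For the measured compounds named here, all three values lie close together, and no step between them is beyond the scatter. Compound 2 and compound 3 share the same atoms joined differently: 3-chlorophenyl in place of 2-chlorophenyl on an aromatic carbon. That rearrangement gave a 1.5-fold higher number from compound 2 to compound 3 (0.17 log units; within the scatter). The change from compound 2 to compound 1 is phenyl in place of furan-2-yl on an aromatic carbon, and it gave a 1.1-fold lower number from compound 2 to compound 1 (0.04 log units; within the scatter).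

Compound 4 `Oc1ccc(-c2cc(-c3ccccc3)nc(-c3cccc(Cl)c3)c2)cc1` is not yet measured. Going by the values given here, it relates to compound 3 by phenyl in place of furan-2-yl on an aromatic carbon, the same kind of change as the one from compound 2 to compound 1, though the surroundings differ: here the place is meta to a 3-chlorophenyl group, while before it was meta to a 2-chlorophenyl group. The expectation for compound 4 rests on compound 2 and compound 1, because a 1.1-fold lower number from compound 2 to compound 1 (0.04 log units; within the scatter) was small, so the step from compound 3 to compound 4 is expected to be a 1.1-fold lower number from compound 3 to compound 4 (0.04 log units; within the scatter). Compound 4 is therefore estimated at 7300 nM in this assay, plausibly between 3500 nM and 15000 nM.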

Compound 4, half-maximal inhibitory concentration: 6100 nM
Beside the measured number, compound 4's estimate is 1.2-fold (0.08 log units) above it; measured number inside the range.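

In this assay, putting phenyl in place of furan-2-yl on the core bearing the 3-chlorophenyl group gave a 1.3-fold lower number from compound 3 to compound 4 (0.12 log units; within the scatter), and this step agrees with the same swap on the core bearing the 2-chlorophenyl group: the same change on two cores in this assay, a 1.1-fold lower number (0.04 log units; within the scatter) from compound 2 to compound 1 and a 1.3-fold lower number (0.12 log units; within the scatter) from compound 3 to compound 4, 1.2-fold (0.08 log units) apart, within the scatter of two such steps. Putting 3-chlorophenyl in place of 2-chlorophenyl gave a 1.2-fold higher number from compound 1 to compound 4 (0.09 log units; within the scatter), which likewise agrees with the same change made earlier on a different core: the same change on two cores in this assay, a 1.5-fold higher number (0.17 log units; within the scatter) from compound 2 to compound 3 and a 1.2-fold higher number (0.09 log units; within the scatter) from compound 1 to compound 4, 1.2-fold (0.08 log units) apart, within the scatter of two such steps. For the compounds shown here, each change therefore behaved alike on the two cores tested, but every step is within the scatter, so the data show only that neither change shifted the number measurably here, not that either has a real effect that carries over, and not that the same would hold on other cores.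

From the compounds shown here alone, all four compounds keep the 4-hydroxyphenyl group and a chlorophenyl group, so what happens when the hydroxyl gives way to a methoxy group remains open. Also open, going by these compounds, is whether an amine or a carboxylic acid on the phenyl ring would produce a step beyond the scatter.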